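Permeability notes: aryl ether in place of trifluoromethylphenyl

A few compounds are considered here, and "the series" means these few. Any claim that something is new, unique, unknown or untested is made for them only; others in the source may bear on it.

Measured so far in an ADME assay for permeability, using PAMPA, with a stated time of 30 min, at pH 7.4; on this read-out lower numbers stand for lower permeability and higher numbers for higher permeability:
compound 1, `COc1ccc(F)cc1CNCCCNc1ccnc2cc(C3CCCCC3)ccc12`, gives 23 10^-6 cm/s
compound 2, `COc1ccc(F)cc1CNCCCNc1ccnc2cc(-c3ccc(C(F)(F)F)cc3)ccc12`, gives 237 10^-6 cm/s

Compound 2 stands highest of the two numbers in this assay; its nearest neighbour is compound 1, and the step of a 10-fold higher number from compound 1 to compound 2 (1.01 log units; beyond the scatter) is large and well beyond the scatter. Compound 3, `COc1ccc(F)cc1CNCCCNc1ccnc2cc(Oc3cccc(N(C)C)c3)ccc12`, is not yet measured. It differs from compound 2 at the same position where compound 1 and compound 2 differ: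

3-(dimethylamino)phenoxy in place of 4-(trifluoromethyl)phenyl on an aromatic carbon

For the measured compounds named here, no measured pair shows an aryl group exchanged for an aryloxy group, so no step bears directly on this change. Going by the values given here, the one step in hand, a 10-fold higher number from compound 1 to compound 2 (1.01 log units; beyond the scatter), only shows that a change at this position can move the number a long way. Given that the group entering carries two hydrogen-bond acceptors where the group leaving carries none, the number for compound 3 is expected to fall below that of compound 2, with the step of a 3.0-fold lower number from compound 2 to compound 3 (0.47 log units; beyond the scatter) estimated as moderate. Compound 3 is estimated at 80 10^-6 cm/s, within a range of 25 10^-6 cm/s to 250 10^-6 cm/s.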

Compound 3, apparent permeability in the ADME assay: 317 10^-6 cm/s
Compound 3: middle estimate off by 4.0-fold (0.60 log units), on the low side, and the stated range ends below it.
By their numbers in the ADME assay, from the lowest: compound 1; then compounds 2 and 3 (each within the scatter of the next).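

In the ADME assay the exchange of 4-(trifluoromethyl)phenyl for 3-(dimethylamino)phenoxy gives a 1.3-fold higher number from compound 2 to compound 3 (0.13 log units; within the scatter), so the two groups cannot be told apart on this read-out, although the entering group has an oxygen link and hydrogen-bond acceptors that the leaving group lacks. Against cyclohexyl, the new group gives a 14-fold higher number from compound 1 to compound 3 (1.14 log units; beyond the scatter), so both groups with a six-membered aromatic ring of carbon only now stand clear of compound 1, with compound 1 as the only cyclohexyl example. In a physicochemical assay for acid dissociation, compound 2 gives 9.47 and compound 3 gives 9.28, and a number 0.19 log units lower from compound 2 to compound 3 (within the scatter) leaves these two apart by no more than the scatter; nothing at hand offers a cause for any of these results.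

The compounds shown do not separate the contribution of the oxygen link from that of the dimethylamino group, which plain phenoxy and 3-(dimethylamino)phenyl at this position would address. Also open, as far as these compounds go, is whether the result holds for a group carrying a carboxylic acid, or for a morpholine ring in place of the dimethylamino group.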